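One Methyl Fewer on a Shared Core

A few compounds are considered here, and "the series" means these few. Any claim that something is new, unique, unknown or untested is made for them only; others in the source may bear on it.

In a functional assay on MDA-MB-231 cells (Homo sapiens) for antiproliferative activity, read by MTT assay (on this read-out higher numbers stand for weaker inhibition and lower numbers for stronger inhibition), compound 1 `CC/C=C\C/C=C\C/C=C\CCCCCCCc1cc(=O)c2c(O)cc(O)cc2o1` gives 6790 nM. Compound 2 `CC/C=C\C/C=C\C/C=C\CCCCCCCc1cc(=O)c2c(O)c(C)c(O)c(C)c2o1` carries methyl groups on the shared core that compound 1 lacks, and compound 2 gives 6790 nM, so it stands level with compound 1 within the usual scatter of such measurements. Compound 3 `CC/C=C\C/C=C\C/C=C\CCCCCCCc1cc(=O)c2c(O)c(C)c(O)cc2o1` has not yet been measured. It differs from compound 2 in one place: hydrogen in place of methyl on an aromatic carbon. This edit brings compound 2 structurally closer to compound 1. No step beyond the scatter is expected in this assay, in either direction, because compound 2 at 6790 nM and compound 1 at 6790 nM show the same figure. The expected size of the move is no change at the digits printed from compound 2 to compound 3 (within the scatter). For compound 3 the estimated value is 6790 nM, with an expected range of 3000 nM to 14000 nM.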

Compound 3, half-maximal inhibitory concentration: 6790 nM
Beside the measured number, compound 3's estimate shows no gap at the digits printed, within the range that was stated.
By their numbers in this assay, from the lowest: compounds 1, 2 and 3 (each within the scatter of the next).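

Compounds 1 and 2 differed by two methyl groups at once, so on their own they could not show what either methyl does alone. In this assay the single methyl on the aromatic carbon ortho to a fused ring and ortho to a hydroxy group can now be read alone: taking it away gives no change at the digits printed from compound 2 to compound 3 (within the scatter), and the other methyl, read alone, gives no change at the digits printed from compound 1 to compound 3 (within the scatter), so neither methyl on its own moves the value beyond the scatter. Nothing measured here explains why this carbon tolerates either hydrogen or methyl.

From the compounds shown here alone, whether this carbon would accept something other than hydrogen or methyl, such as an ethyl group, a chlorine atom or an amine, remains open. So does whether the flat result would hold with a shorter chain on the shared core.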